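The compounds below may be only part of what the source reports. "The series", "measured", "known", "first", "only" and "open" are said of these compounds alone.

Working notes on the series, all read in an in vitro ADME assay on microsomes from liver (Homo sapiens) for metabolic stability; a higher number here means that the compound lasts longer, a lower number that the compound disappears faster. Compound 1 `CS(=O)(=O)Nc1ccc2c(c1)S(=O)(=O)N=C(C1=C(O)C3CCCC3N(CCC3CC3)C1=O)N2` gives 0.417 h, and compound 3 `CS(=O)(=O)Nc1ccc2c(c1)S(=O)(=O)N=C(C1=C(O)C3CCCC3N(Cc3cccc(F)c3)C1=O)N2` gives 0.85 h, the higher of these two numbers. Compound 2 `CS(=O)(=O)Nc1ccc2c(c1)S(=O)(=O)N=C(C1=C(O)C3CCCC3N(Cc3ccc(Cl)cc3)C1=O)N2` reads > 1 h, which is a limit of the assay and not a number. The next structure is compound 4 `CS(=O)(=O)Nc1ccc2c(c1)S(=O)(=O)N=C(C1=C(O)C3CCCC3N(Cc3ccccc3)C1=O)N2`, and the change is hydrogen in place of fluoro on an aromatic carbon, meta to a large group.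

Among the measured compounds shown here, no measured step removes a substituent from the phenyl ring directly, so three steps bear on it only indirectly. Replacing cyclopropylmethyl with an aryl group gives a 2.0-fold higher number from compound 1 to compound 3 (0.31 log units; beyond the scatter) and also an at least 2.3-fold higher number from compound 1 to compound 2 (0.37 log units; beyond the scatter), so the largest measured effects belong to that exchange. Compound 4 keeps the phenyl ring and does not reverse that exchange. The exchange of one substituted phenyl for another gives an at least 1.1-fold lower number from compound 2 to compound 3 (0.07 log units; that floor lies within the scatter), a step bounded on one side only. On this basis no step beyond the scatter is expected in this assay, with a slight downward drift as the likelier direction. The expected change is a 1.2-fold lower number from compound 3 to compound 4 (0.08 log units; within the scatter). For compound 4 the estimate is 0.7 h, with an expected range of 0.4 h to 1.2 h.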

Compound 4, half-life: 0.833 h
The estimate for compound 4 lay 1.2-fold (0.08 log units) below the measured number; the measured number falls inside the stated range.
By their numbers in this assay, from the lowest: compounds 1, 4 and 3 (each within the scatter of the next, the first and the last beyond it). At a limit, above all of these: compound 2.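

In this assay, among the compounds shown here, hydrogen in place of fluoro on an aromatic carbon, meta to a large group, gives the first direct reading at this position, and the change stays inside the scatter: a 1.0-fold lower number from compound 3 to compound 4 (0.01 log units; within the scatter). The phenyl without a substituent gives a 2.0-fold higher number from compound 1 to compound 4 (0.30 log units; within the scatter), a step printed as within the scatter, whereas the step with 3-fluorophenyl, a 2.0-fold higher number from compound 1 to compound 3 (0.31 log units; beyond the scatter), is printed as beyond it, so these two steps sit on either side of that line while compound 3 and compound 4 remain within the scatter of each other. The exchange of chloro for hydrogen gives only a floor, an at least 1.2-fold lower number from compound 2 to compound 4 (0.07 log units; that floor lies within the scatter), and cannot be read as a size, because compound 2 sits at a limit of the assay: the limit of > 1 h in this assay, at which 1 of the 4 values shown sits.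

Going by these compounds, it remains open whether a nitrile, a methoxy or an amine on this aromatic carbon would move the number beyond the scatter, and whether hydrogen in place of fluoro reads the same on the other aromatic carbons of the ring. On these data alone, how chloro compares with fluoro or hydrogen in size also stays open, since only a floor is available for compound 2.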